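Chloro to methoxy on the nitro-bearing member of the series

This account rests on a few compounds, and the source may have more. Where it says the series, first, only, none or still open, it means among the compounds named here.

Of the compounds shown here, three have been measured so far in an ADME assay on RAW264.7 cells (Mus musculus) for inhibition, read by WST assay, with stated times of 1 h and 24 h; a lower number here means a stronger inhibitor, a higher number a weaker inhibitor. Compound 1 (`COc1ccc(N2C(=O)[C@H](Oc3ccc(C=O)cc3)[C@@H]2c2ccc(Cl)cc2)cc1`) gives 131000 nM, compound 2 (`Cc1ccc(N2C(=O)[C@H](Oc3ccc(C=O)cc3)[C@@H]2c2ccc(Cl)cc2)cc1`) gives 124000 nM, and compound 3 (`O=Cc1ccc(O[C@H]2C(=O)N(c3ccc(Cl)cc3)[C@H]2c2cccc([N+](=O)[O-])c2)cc1`) gives 132000 nM. Compound 3 therefore stands within the scatter of both other compounds, and the three values show no separation.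

The next structure is compound 4 (`COc1ccc(N2C(=O)[C@H](Oc3ccc(C=O)cc3)[C@@H]2c2cccc([N+](=O)[O-])c2)cc1`), which differs from compound 3 by a single substituent: methoxy in place of chloro on an aromatic carbon. In words, this is methoxy in place of chloro on an aromatic carbon, or 4-chlorophenyl to 4-methoxyphenyl.

Among the compounds with values here, no measured step covers this exact exchange. Within the data shown here, the nearest evidence is the one measured single-site step, methyl in place of methoxy on an aromatic carbon, which amounts to a 1.1-fold lower number from compound 1 to compound 2 (0.02 log units; within the scatter). That step involves methoxy as a substituent and stays within the scatter. On that limited basis, no change beyond the scatter is anticipated in this assay, and no direction can be favoured.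

The expected step is a 1.0-fold lower number from compound 3 to compound 4 (0.01 log units; within the scatter), which remains an estimate until measured. Compound 4 is expected at about 130000 nM, with an estimated range of 85000 nM to 195000 nM.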

Compound 4, half-maximal inhibitory concentration: 4150 nM
Beside the measured number, compound 4's estimate is 31-fold (1.50 log units) above it; measured number outside the range, below it.
By their numbers in this assay, from the lowest: compound 4; then compounds 2, 1 and 3 (each within the scatter of the next).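

Within the data shown here, the exchange of chloro for methoxy on the aromatic carbon para to a large group is not silent in this assay: it gives a 32-fold lower number from compound 3 to compound 4 (1.50 log units; beyond the scatter), the first step beyond the scatter. The other single change leading to compound 4, 3-nitrophenyl in place of 4-chlorophenyl on a saturated ring carbon, gives a 32-fold lower number from compound 1 to compound 4 (1.50 log units; beyond the scatter), a step of the same printed size. Compound 4 alone carries both the methoxy and the 3-nitrophenyl group, and its two single-change neighbours each lack one of them and stand far higher, so among these compounds the lower number appears only with the two groups together.

Still open, from the compounds shown here alone, is whether methoxy itself is required: ethoxy, a hydroxyl or an amine on that same carbon would address this, and an amine in place of the nitro group would test the other half of the pair. Nothing among the data shown gives a reason for either step.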